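Anilino to piperidin-1-yl on the shared core

A few compounds are considered here, and "the series" means these few. Any claim that something is new, unique, unknown or untested is made for them only; others in the source may bear on it.

Measured so far in a functional assay on ECa-109 cells for inhibition, with ECa-109 cell line (Homo sapiens) as the target, read by sulforhodamine B assay; a higher number here means a weaker inhibitor, a lower number a stronger inhibitor

compound 1 `O=C1C(Nc2ccccc2)=CC(=O)c2c1nc1n2[C@H]2OC[C@@H](O)[C@H]2OC1` gives 3560 nM
compound 2 `O=C1C=C(N2CCC2)C(=O)c2c1nc1n2[C@H]2OC[C@@H](O)[C@H]2OC1` gives > 16000 nM (a limit, not a number)
compound 3 `O=C1C=C(Nc2ccccc2F)C(=O)c2c1nc1n2[C@H]2OC[C@@H](O)[C@H]2OC1` gives 2760 nM

Within the data shown here, compound 1 and compound 3 hold the only two exact numbers, and these lie within the scatter of each other. Compound 2 reports only a limit.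

Next is compound 4 `O=C1C(N2CCCCC2)=CC(=O)c2c1nc1n2[C@H]2OC[C@@H](O)[C@H]2OC1` with piperidin-1-yl in place of anilino on a double-bonded ring carbon. One aromatic ring thus gives way to a non-aromatic one.

Among the measured compounds shown here, one measured step bears on this (an at least 5.7-fold lower number from compound 2 to compound 3 (0.76 log units; beyond the scatter)) and lies beyond the scatter, with (2-fluorophenyl)amino in place of azetidin-1-yl. It is a single step, its size is a bound, and azetidin-1-yl is not piperidin-1-yl, so the parallel is loose. Read in reverse, it points to a higher number for compound 4 than for compound 1. The expected size in this assay is a 2.5-fold higher number from compound 1 to compound 4 (0.40 log units; beyond the scatter) as an estimate, and a reading at the limit would be no surprise. The estimate for compound 4 is 9000 nM as the expected value, with 3000 nM to 27000 nM as its range.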

Compound 4, half-maximal inhibitory concentration: > 8000 nM
Compound 4 ended at the assay's limit (the forecaster's own chance of this, stated with the estimate: 30%); the middle value does not contradict the limit.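

Replacing anilino with piperidin-1-yl in this assay gives an at least 2.2-fold higher number from compound 1 to compound 4 (0.35 log units; beyond the scatter), the first step read directly from compound 1, and it shows that this double-bonded ring carbon does not tolerate the exchange without a loss. Among these compounds, compound 4 gives > 8000 nM, which is a limit of the assay and not a number: the limit of > 8000 nM in this assay, at which 1 of the 4 values shown sits. Among the four compounds, both non-aromatic rings, azetidin-1-yl in compound 2 and piperidin-1-yl in compound 4, end at limits, both groups with an aromatic ring give exact numbers, and no compound goes against this.

The compounds shown leave open how large the step to compound 4 really is. They also leave open whether it follows the aromatic ring or the hydrogen-bond donor, which cyclohexylamino and N-methylanilino at this carbon would separate.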